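The compounds below may be only part of what the source reports. "The series", "measured", "known", "first", "only" and "open" are said of these compounds alone.

Of the compounds shown here, three built on one shared core have been tested so far, and none has yet given a number. In an ADME assay on MCF-10A cells (Homo sapiens) for inhibition, with a stated time of 48 h (on this read-out lower numbers stand for stronger inhibition and higher numbers for weaker inhibition), compound 1 (`O=C(Nc1ccc(Cl)cc1)N1CCC[C@H]1c1nc(-c2ccccc2)no1`) gives > 50000 nM and this is a limit of the assay, not a number. Compound 2 (`O=C(Nc1ccc([N+](=O)[O-])cc1)N1CCC[C@H]1c1nc(-c2ccccc2)no1`) gives > 50000 nM and this too is a limit. Compound 3 (`O=C(Nc1ccc(Cl)cc1)N1CCC[C@H]1c1nc(-c2cccc(Br)c2)no1`) gives > 50000 nM and this is also a limit, so it has no exact place on the scale. Among the measured compounds shown here, the whole series so far comes down to the limit of > 50000 nM in this assay, at which 3 of the 3 values shown sit, and nothing finer.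

The next compound is compound 4 (`O=C(Nc1ccc(Cl)cc1)N1CCC[C@H]1c1nc(-c2ccc(I)cc2)no1`), with 4-iodophenyl in place of 3-bromophenyl on an aromatic carbon of a five-membered aromatic ring with 2 nitrogen and 1 oxygen (4-iodophenyl in place of 3-bromophenyl on an aromatic carbon). Two measured steps offer some guidance. Nitro in place of chloro on an aromatic carbon gave a step that the two limits leave unreadable from compound 1 to compound 2 and bromo in place of hydrogen on an aromatic carbon gave a step that the two limits leave unreadable from compound 1 to compound 3 so neither has a size that can be read. Resting on a step that the two limits leave unreadable from compound 1 to compound 3 no step beyond the usual scatter is expected in either direction, and the estimate in this assay is a number no higher from compound 3 to compound 4 (the limit leaves the size open) for now. Compound 4 is therefore expected to sit near 50000 nM with an estimated range from 25000 nM to 100000 nM and it may well turn out to be only a limit again.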

Compound 4, half-maximal inhibitory concentration: > 50000 nM
Compound 4: no number, only a limit (the forecaster's own chance of this, stated with the estimate: 85%); the middle value sits exactly at the limit.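

Compound 4 is again only a limit and not a number, so neither its step from compound 3 nor its step from compound 1 can be read, and the series stays where it stood: the limit of > 50000 nM in this assay, at which 4 of the 4 values shown sit. The compounds shown leave open whether any of them has a measurable value in this assay and how far they truly differ.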